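A few compounds are considered here, and "the series" means these few. Any claim that something is new, unique, unknown or untested is made for them only; others in the source may bear on it.

Compounds measured so far:

compound 1 `CN(C)C(=O)Cn1nnc(CNC(=O)c2ccc(-c3ccccc3)cc2)n1` — > 10000 nM
compound 2 `CC(=O)Cn1nnnc1CNC(=O)c1ccc(-c2ccccc2)cc1` — > 10000 nM

Both compounds were tested in an assay on isolated protein (COS cells) for inhibition of diacylglycerol lipase-alpha (Homo sapiens); a higher number here means a weaker inhibitor, a lower number a stronger inhibitor. For compound 1 only a limit is known: the value > 10000 nM is the limit of this assay, not a number, so it is only known that compound 1 is at most a weak inhibitor. Compound 2 carries a different substituent on its core and differs from compound 1 in more than one place. In this assay compound 2 also reaches only the limit > 10000 nM. Thus every value obtained so far sits at the limit of > 10000 nM in this assay, at which 2 of the 2 values shown sit, and no step between two measured compounds can be read.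

Compound 3 `COC(=O)Cn1nnc(CNC(=O)c2ccc(-c3ccccc3)cc2)n1` is a close relative of compound 1: the change is methoxy in place of dimethylamino on a carbonyl carbon. Within the data shown here, no measured step tells how such a change acts here. Given that compound 1 stops at > 10000 nM, the expectation is that this step, a step that the limit leaves unreadable from compound 1 to compound 3, will not move the result beyond the scatter, and that compound 3 will most likely again be reported only as a limit. The estimate for compound 3 is therefore 15000 nM, with a range from 5000 nM to 50000 nM.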

Compound 3, half-maximal inhibitory concentration: > 10000 nM
Compound 3 gave a limit, no number; the forecaster's own chance of this, stated with the estimate: 80%; the middle value lies beyond the limit too.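

Compound 1 and compound 3 each give only a limit, not a number, in this assay, and the step between them, methoxy in place of dimethylamino on a carbonyl carbon, cannot be read. All results so far stand at the same point: the limit of > 10000 nM in this assay, at which 3 of the 3 values shown sit. The compounds shown leave open which change, if any, would give a measurable value.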